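A few compounds are considered here, and "the series" means these few. Any claim that something is new, unique, unknown or untested is made for them only; others in the source may bear on it.

Of the compounds shown here, two of the shared core have been measured in a functional assay on LOX IMVI cells (Homo sapiens) for inhibition, read by sulforhodamine B assay, with a stated time of 48 h; a higher number here means a weaker inhibitor of growth, a lower number a stronger inhibitor of growth. Compound 1 `O=C(Nc1cccc(-n2cc(-c3ccncc3)c(-c3ccc(Cl)c(O)c3)n2)c1)Nc1cccc(C(F)(F)F)c1` gives 9580 nM in this assay. Compound 2 `COc1cc(-c2nn(-c3cccc(NC(=O)Nc4ccc(Cl)c(Cl)c4)c3)cc2-c2ccncc2)ccc1Cl` gives 2620 nM in this assay, the lowest of the two numbers, and the gap to compound 1 lies beyond the usual scatter. Compound 1 and compound 2 differ in two places at once, so nothing can be read from them about either change on its own.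

Compound 3 `O=C(Nc1cccc(-n2cc(-c3ccncc3)c(-c3ccc(Cl)c(O)c3)n2)c1)Nc1ccc(Cl)c(Cl)c1` is the next compound. Compared with compound 2 the change is hydrogen in place of methyl on an oxygen on an aromatic ring: a methoxy becomes a hydroxy, giving a 4-chloro-3-hydroxyphenyl group in place of the 4-chloro-3-methoxyphenyl group. Within the data shown here, no measured pair shows this change alone. The step from compound 2 to compound 3 in this assay is expected to be small, a 1.3-fold higher number from compound 2 to compound 3 (0.13 log units; within the scatter), with no direction claimed beyond the scatter. Compound 3 is therefore estimated at 3500 nM in this assay, within a range from 1400 nM to 9000 nM.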

Compound 3, concentration for total growth inhibition: 3570 nM
Compound 3: the middle estimate sits 1.0-fold (0.01 log units) below what was measured, within the range that was stated.
By their numbers in this assay, from the lowest: compounds 2 and 3 (each within the scatter of the next); then compound 1.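

In this assay the change from methoxy to hydroxy gives a 1.4-fold higher number from compound 2 to compound 3 (0.13 log units; within the scatter) and so, on this oxygen on an aromatic ring, losing the methyl leaves no difference that can be told from the scatter. Among these compounds, compound 3 also pulls apart the two changes mixed together between compound 1 and compound 2: with the hydroxy held fixed, 3,4-dichlorophenyl in place of 3-(trifluoromethyl)phenyl on the amide-type nitrogen gives a 2.7-fold lower number from compound 1 to compound 3 (0.43 log units; beyond the scatter) in this assay and this modest step is the first single change here that lies beyond the scatter. Nothing available explains either step.

Going by these compounds, whether the gain from 3,4-dichlorophenyl would also appear with a methoxy in place of the hydroxy stays open. So does the effect of other groups on this position of the ring, such as an amine or a longer chain like ethoxy.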